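The compounds below may be only part of what the source reports. "The series", "measured", "known", "first", "only" and "open" are said of these compounds alone.

Measured so far in an ADME assay on Huh-7 cells (Homo sapiens) for cytotoxicity; a lower number here means that less compound is tolerated, a higher number that more compound is tolerated:
compound 1 `CN1CCN(CCCNCc2cn(-c3ccc(C(F)(F)F)cc3)nc2-c2ccc(C(F)(F)F)cc2)CC1` gives 2000 nM.
compound 2 `Cc1ccccc1-c1nn(-c2ccc(F)cc2)cc1CNCCN1CCN(C)CC1` gives > 20000 nM, which is a limit of the assay and not a number.

Compound 2 therefore stands at the limit of > 20000 nM in this assay, at which 1 of the 2 values shown sits; its own value gives no direction for the next step. Compound 3 `Cc1ccccc1-c1nn(-c2cccc(C(F)(F)F)c2)cc1CNCCN1CCN(C)CC1` differs from compound 2 by 3-(trifluoromethyl)phenyl in place of 4-fluorophenyl on an aromatic nitrogen. For the measured compounds named here, no measured step covers this change. Compound 1, which carries two trifluoromethylphenyl groups, gives 2000 nM in this assay , a lower tolerated concentration. On that basis a downward step, an at least 2.5-fold lower number from compound 2 to compound 3 (0.39 log units; beyond the scatter), is expected, though a limit read-out remains possible. Compound 3 is estimated at 8000 nM, within 2500 nM to 20000 nM.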

Compound 3, half-maximal cytotoxic concentration: 18000 nM
For compound 3 the middle estimate is 2.3-fold (0.35 log units) below the measured one; low and high end bracket the measured number.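

In this assay, 3-(trifluoromethyl)phenyl in place of 4-fluorophenyl on an aromatic nitrogen gives an at least 1.1-fold lower number from compound 2 to compound 3 (0.04 log units; that floor lies within the scatter). This is the first step read at this position, and its floor lies within the scatter, so the change is not shown to lower the number beyond it. The true size of the step stays unread because compound 2 has a limit of the assay and not a number: the limit of > 20000 nM in this assay, at which 1 of the 3 values shown sits.

Still open, on these data alone, is whether a phenyl group carrying a carboxylic acid or an amine on this nitrogen would move the number beyond the scatter.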